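A Chloro for Dimethylamino Swap in an Imine Series

The compounds below may be only part of what the source reports. "The series", "measured", "known", "first", "only" and "open" are said of these compounds alone.

Measured compounds:
compound 1 `Cc1c(/N=C/c2ccc(N(C)C)cc2)c(=O)n(-c2ccccc2)n1C`: 331000000 nM
compound 2 `COc1cccc(/C=N/c2c(C)n(C)n(-c3ccccc3)c2=O)c1O`: 240000000 nM

In a functional assay on HT-29 cells (Homo sapiens) for cytotoxicity, read by MTT assay, with a stated time of 72 h (on this read-out higher numbers stand for weaker inhibition and lower numbers for stronger inhibition), compound 1 gives the highest of the two numbers, but compound 2, with 240000000 nM, sits within the usual scatter of it, so the two are not told apart. Compound 3 `Cc1c(/N=C/c2ccc(Cl)cc2)c(=O)n(-c2ccccc2)n1C` differs from compound 1 by one change: chloro in place of dimethylamino on an aromatic carbon. Within the data shown here, no step between two measured compounds that differ in a single place is available, so the size of this swap cannot be read from the data. Both measured compounds give numbers of the same order, and the change is expected to move this assay by no step beyond the scatter. For compound 3 the estimated value is 250000000 nM, with a range from 80000000 nM to 800000000 nM. This estimate corresponds to an expected step of a 1.3-fold lower number from compound 1 to compound 3 (0.12 log units; within the scatter).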

Compound 3, half-maximal inhibitory concentration: 309000000 nM
Compound 3: the middle estimate sits 1.2-fold (0.09 log units) below what was measured, within the range that was stated.
By their numbers in this assay, from the lowest: compounds 2, 3 and 1 (each within the scatter of the next).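

In this assay the series gains its first step between compounds that differ in one place (a 1.1-fold lower number from compound 1 to compound 3 (0.03 log units; within the scatter)), and that step lies within the scatter. On an aromatic carbon of the six-membered aromatic ring, para to a large group, chloro and dimethylamino are therefore not told apart, although dimethylamino brings more heavy atoms and a hydrogen-bond acceptor that chloro lacks. No measured property bears on this result, and the data give no reason for it.

The compounds shown leave open whether this position stays as flat with other groups, such as a carboxylic acid, a primary amine or a longer alkyl chain. They also rest on this single swap, so whether the same holds on another core remains unanswered.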